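From compound 2 to compound 3: one group exchanged

A few compounds are considered here, and "the series" means these few. Any claim that something is new, unique, unknown or untested is made for them only; others in the source may bear on it.

Measured in a functional assay on the whole organism with Canis familiaris (Canis lupus familiaris) as the target; on this read-out lower numbers stand for an effect already at smaller amounts and higher numbers for an effect only at larger amounts of compound:
- compound 1 `Nc1nc(SCC(O)CN2CCN(C(c3ccc(F)cc3)c3ccc(F)cc3)CC2)c2[nH]cnc2n1`: 0.85 mg/kg
- compound 2 `CN(CC(O)CN1CCN(C(c2ccc(F)cc2)c2ccc(F)cc2)CC1)c1[nH]cnc2ncnc1-2`: 0.74 mg/kg

Only these two compounds have been measured so far. In this assay, compound 2 stands at 0.74 mg/kg, level within the scatter with compound 1 at 0.85 mg/kg. The next compound to be measured is compound 3 `OC(COc1[nH]cnc2ncnc1-2)CN1CCN(C(c2ccc(F)cc2)c2ccc(F)cc2)CC1`. It differs from compound 2 in one place, on a saturated chain carbon, two bonds along the chain from an oxygen on a saturated carbon: a group of 10 heavy atoms (5 carbon, 4 nitrogen, 1 oxygen; one five-membered aromatic ring with 2 hetero atoms, one six-membered aromatic ring with 2 hetero atoms) in place of a group of 11 heavy atoms (6 carbon, 5 nitrogen; one five-membered aromatic ring with 2 hetero atoms, one six-membered aromatic ring with 2 hetero atoms), on a saturated chain carbon, two bonds along the chain from an oxygen on a saturated carbon.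

Among the compounds with values here, one measured step bears on this change, because it exchanges a group at the same place: a 1.1-fold lower number from compound 1 to compound 2 (0.06 log units; within the scatter). That exchange left the number within the scatter. It is a single step, however, and compound 3 carries a group that neither measured compound has, so the evidence is thin and the range should stay wide. No shift beyond the scatter is expected in either direction, and the expected step is a 1.1-fold higher number from compound 2 to compound 3 (0.03 log units; within the scatter). For compound 3 the estimate is 0.8 mg/kg, with an expected range from 0.3 mg/kg to 2 mg/kg.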

Compound 3, dose for half-maximal effect: 0.72 mg/kg
The estimate for compound 3 lay 1.1-fold (0.05 log units) above the measured number, and the stated range covers the measured number.
By their numbers in this assay, from the lowest: compounds 3, 2 and 1 (each within the scatter of the next).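

In this assay, the group of 10 heavy atoms in compound 3 stands level with the group of 11 heavy atoms it replaces (a 1.0-fold lower number from compound 2 to compound 3 (0.01 log units; within the scatter)), and it stands level with the sulfur-bearing group of compound 1 as well (a 1.2-fold lower number from compound 1 to compound 3 (0.07 log units; within the scatter)). Where the earlier compounds gave a single exchange at this saturated chain carbon, there are now three groups with different atom counts, one with sulfur, one with five nitrogens and no sulfur, and one with oxygen, and all three pairs lie within the scatter, so this read-out has not yet separated any groups at this place. No measurement is available that would account for this level result.

As far as these compounds go, all three groups carry the same pair of aromatic rings, so it remains open whether a group lacking that pair, such as a simple phenyl ring, a plain dimethylamine or a carboxylic acid, would shift the number beyond the scatter. The rest of the structure is identical across compounds 1, 2 and 3, which leaves open how much an exchange elsewhere, for instance of the fluorine atoms for chlorine, would matter.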